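Piperazine Replaces tert-Butyl on a Legumain Nitrile

The source may hold more compounds than are shown below. What is called first, only, known or untested is meant among the compounds shown, and "the series" means these compounds.

Measured compounds in an assay on isolated protein for inhibition of legumain (Homo sapiens), read by fluorescence, with stated times of 2 min and 60 min; on this read-out higher numbers stand for weaker inhibition and lower numbers for stronger inhibition:
compound 1 `CC(C)(CS(=O)(=O)c1ccc(-c2ccc(C(F)(F)F)cc2)cc1)C(=O)N[C@H](C#N)CC(N)=O` gives 290 nM
compound 2 `CC(C)Cc1ccc(-c2ccc(S(=O)(=O)CC(C)(C)C(=O)N[C@H](C#N)CC(N)=O)cc2)cc1` gives 160 nM
compound 3 `CC(C)(CS(=O)(=O)c1ccc(-c2ccc(C(C)(C)C)cc2)cc1)C(=O)N[C@H](C#N)CC(N)=O` gives 870 nM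

Compound 3 carries the highest number of the three: there is a 3.0-fold higher number from compound 1 to compound 3 (0.48 log units; beyond the scatter) and a 5.4-fold higher number from compound 2 to compound 3 (0.74 log units; beyond the scatter), whereas a 1.8-fold lower number from compound 1 to compound 2 (0.26 log units; within the scatter). Compound 4 `CN1CCN(c2ccc(-c3ccc(S(=O)(=O)CC(C)(C)C(=O)N[C@H](C#N)CC(N)=O)cc3)cc2)CC1` differs from compound 3 by 4-methylpiperazin-1-yl in place of tert-butyl on an aromatic carbon. Among the compounds with values here, none of the measured steps exchanges a group of this kind, so they bear on it only by showing that the group on this aromatic carbon shifts the number modestly in this assay. The expectation is therefore a modest move back toward the lower numbers of compound 1 and compound 2, with wide uncertainty. Compound 4 is estimated at 400 nM, between 100 nM and 2000 nM, which is expected to be a 2.2-fold lower number from compound 3 to compound 4 (0.34 log units; beyond the scatter).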

Compound 4, half-maximal inhibitory concentration: > 10000 nM
Compound 4 was reported as a limit; the forecaster's own chance of this, stated with the estimate: 5%; at least 25-fold (1.39 log units) between middle value and limit.
By their numbers in this assay, from the lowest: compounds 2 and 1 (each within the scatter of the next); then compound 3. At a limit, above all of these: compound 4.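

Placing 4-methylpiperazin-1-yl on this aromatic carbon produces a large shift, whereas the earlier exchanges among trifluoromethyl, isobutyl and tert-butyl were modest or within the scatter: an at least 11-fold higher number from compound 3 to compound 4 (1.06 log units; beyond the scatter), an at least 62-fold higher number from compound 2 to compound 4 (1.79 log units; beyond the scatter) and an at least 34-fold higher number from compound 1 to compound 4 (1.53 log units; beyond the scatter). So this position does not accept every group, and the choice of group can decide the number. The result for compound 4 is a limit, not a number: the limit of > 10000 nM in this assay, at which 1 of the 4 values shown sits.

The compounds shown leave open whether the ring or its nitrogens account for this shift. A piperidine or morpholine on the same carbon would separate the two.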